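A few compounds are considered here, and "the series" means these few. Any claim that something is new, unique, unknown or untested is made for them only; others in the source may bear on it.

Within the data shown here, in a functional assay on the whole organism with Rattus norvegicus as the target (on this read-out lower numbers stand for an effect already at smaller amounts and higher numbers for an effect only at larger amounts of compound), compound 1 (`CCCCNc1cccc(NC(=O)C(=O)OCC)c1C#N`) gives 0.3 mg/kg and compound 2 (`CCOC(=O)C(=O)Nc1cccc(N(C)C(C)C)c1C#N`) gives 1.2 mg/kg as the higher of the two numbers, with compound 1 as its only neighbour. Compound 3 (`CCOC(=O)C(=O)Nc1cccc([N+](=O)[O-])c1C#N`) has not yet been measured. It carries nitro in place of isopropyl(methyl)amino on an aromatic carbon, ortho to a cyano group (nitro in place of isopropyl(methyl)amino on an aromatic carbon). Among the measured compounds shown here, the one measured step that bears on this change is a 4.0-fold higher number from compound 1 to compound 2 (0.60 log units; beyond the scatter) and it also replaces a group on an aromatic carbon, though only butylamino by isopropyl(methyl)amino. For the measured compounds named here, no measured compound carries nitro, so that modest step offers a guide to size but none to direction. In this assay the expected outcome is a 1.2-fold lower number from compound 2 to compound 3 (0.08 log units; within the scatter) and no firm direction can be expected. For compound 3 the estimated value is 1 mg/kg with 0.25 mg/kg to 4 mg/kg as the expected range.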

Compound 3, dose for half-maximal effect: 82 mg/kg
For compound 3 the middle estimate is 82-fold (1.91 log units) below the measured one, and the stated range ends below it.
By their numbers in this assay, from the lowest: compound 1; then compound 2; then compound 3.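

In this assay the group on this aromatic carbon, ortho to a cyano group, turns out to matter far more than the exchange of one amino group for another had suggested. Nitro in place of isopropyl(methyl)amino gives a 68-fold higher number from compound 2 to compound 3 (1.83 log units; beyond the scatter), a large step compared with the modest 4.0-fold higher number from compound 1 to compound 2 (0.60 log units; beyond the scatter) between the two amino groups. Nitro in place of butylamino gives the still wider a 270-fold higher number from compound 1 to compound 3 (2.44 log units; beyond the scatter), so both compounds with an amino group at this place lie far from compound 3 in this assay.

Nothing at hand accounts for this gap. The compounds shown do not separate the loss of the amino group from the entry of nitro, and a primary amine, a methoxy group or a chlorine atom on this carbon would be needed to tell the two apart.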